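Chloro to Methoxy on the Aryl Amine

The source may hold more compounds than are shown below. What is called first, only, known or untested is meant among the compounds shown, and "the series" means these compounds.

In a functional assay on HepG2 cells (Homo sapiens) for inhibition, read by MTT assay, with a stated time of 72 h (a lower number here means a stronger inhibitor, a higher number a weaker inhibitor), compound 1 `C#CCSc1nc(Nc2ccccc2)c2ccncc2n1` gives 29400 nM, and compound 2 `C#CCSc1nc(Nc2ccc(Cl)cc2)c2ccncc2n1` gives 36700 nM. Compound 2 stands highest of the two numbers, yet the step of a 1.2-fold higher number from compound 1 to compound 2 (0.10 log units; within the scatter) lies within the scatter. Compound 3 `C#CCSc1nc(Nc2ccc(OC)cc2)c2ccncc2n1` differs from compound 2 by methoxy in place of chloro on an aromatic carbon. Among the measured compounds shown here, no measured step involves a methoxy group; the only step known, a 1.2-fold higher number from compound 1 to compound 2 (0.10 log units; within the scatter), shows that one exchange on that aromatic carbon left this assay essentially unchanged. The number for compound 3 is therefore expected to stay close, a step of a 1.2-fold lower number from compound 2 to compound 3 (0.09 log units; within the scatter) not beyond the scatter. Compound 3 is estimated at 30000 nM, between 12000 nM and 80000 nM.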

Compound 3, half-maximal inhibitory concentration: > 80000 nM
Compound 3: only a limit was reported (the forecaster's own chance of this, stated with the estimate: 15%); middle value at least 2.6-fold (0.42 log units) away from the limit.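

In this assay, the aromatic carbon para to a large group turns out to be sensitive to the group it carries: methoxy in place of chloro gives an at least 2.1-fold higher number from compound 2 to compound 3 (0.33 log units; beyond the scatter), and methoxy in place of hydrogen gives an at least 2.7-fold higher number from compound 1 to compound 3 (0.43 log units; beyond the scatter). Chloro in place of hydrogen stayed within the scatter, so this position's tolerance does not extend to every exchange. The value of compound 3 is a limit, and the full size of both steps stays unknown: the limit of > 80000 nM in this assay, at which 1 of the 3 values shown sits.

The compounds shown leave open whether an amine or a hydroxyl on this carbon would behave like methoxy or like chloro, and what a longer chain such as ethoxy would do.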